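Nitro to benzylamino on the imidazopyridine-type aryl compound

The source may hold more compounds than are shown below. What is called first, only, known or untested is meant among the compounds shown, and "the series" means these compounds.

Measured so far:
compound 1, `CC(=O)Nc1cc(OCc2ccccc2)nc(SCc2ccccc2)n1`: 35200 nM
compound 2, `CC(=O)Nc1cc(=O)n(Cc2ccccc2)c(SCc2ccccc2)n1`: 50400 nM
compound 3, `Cc1ccn2cc(-c3ccc([N+](=O)[O-])cc3)nc2c1`: 62400 nM

All three numbers come from a functional assay on A549 cells (Homo sapiens) for antiproliferative activity, read by MTT assay, with a stated time of 72 h; on this read-out higher numbers stand for weaker inhibition of growth and lower numbers for stronger inhibition of growth. Compound 3 gives the highest of the three, with compound 2 nearest and compound 1 furthest; both gaps lie within the usual scatter, so the three compounds are not separated on this read-out. Among the measured compounds shown here, compounds 1 and 2 share a core with each other and differ from compound 3 in the whole skeleton; no single-point step between measured compounds exists, so nothing is known about how a change at this position moves the number.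

Compound 4, `Cc1ccn2cc(-c3ccc(NCc4ccccc4)cc3)nc2c1`, is the next compound. Its difference from compound 3 is benzylamino in place of nitro on an aromatic carbon, para to a large group. For the measured compounds named here, the closest precedent is only that compounds 1 and 2, which carry a benzyl group, also sit in the weak range.

In this assay the expected step is a 1.4-fold lower number from compound 3 to compound 4 (0.14 log units; within the scatter), not beyond the scatter. Compound 4 is expected at 45000 nM, within 12000 nM to 150000 nM.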

Compound 4, concentration for 50% growth inhibition: 5100 nM
Estimate against measurement, compound 4: 8.8-fold (0.95 log units) above; measured number below the stated range.
By their numbers in this assay, from the lowest: compound 4; then compounds 1, 2 and 3 (each within the scatter of the next).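

In this assay, among the compounds shown here, the change of nitro to benzylamino on an aromatic carbon, para to a large group, gives a 12-fold lower number from compound 3 to compound 4 (1.09 log units; beyond the scatter) and is the first single-place step. It is a large step, beyond the scatter, and shows that the group at this position can move the number substantially while the rest of compound 3 stays the same. No measurement at hand explains the size of this step.

Going by these compounds, it remains open whether the lower number depends on the whole benzylamino group or only on removing nitro, a question that the plain amine or methylamino at the same carbon would address. Also open, on these data alone, is how far the step tolerates change in the added ring, for example a chloro or methoxy group on the benzyl ring, or a longer chain between the nitrogen and that ring.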